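The compounds below may be only part of what the source reports. "The series", "measured", "known", "first", "only" and "open" are said of these compounds alone.

Measured so far in an ADME assay on microsomes from liver (Mus musculus) for metabolic stability, with a stated time of 10 min, tested at 0.5 uM; a lower number here means that less of the compound is left, a higher number that more of the compound is left:
compound 1 (`Cc1noc(C)c1[C@@H]1C[C@@](C)(c2ccc(F)cc2F)N=C(N)S1`) gives 72%
compound 2 (`Cc1onc(-c2ccc(F)cc2)c1[C@@H]1C[C@@](C)(c2ccc(F)cc2F)N=C(N)S1`) gives 23%
compound 3 (`Cc1noc(-c2ccccc2)c1[C@@H]1C[C@@](C)(c2ccc(F)cc2F)N=C(N)S1`) gives 6%

Compound 1 has the highest of these three numbers, and its steps to the other two both lie beyond the usual scatter. Compound 4 (`C[C@@]1(c2ccc(F)cc2F)C[C@@H](c2cncnc2)SC(N)=N1`) has not been measured yet. It keeps the core of compound 1 but has pyrimidin-5-yl in place of 3,5-dimethyl-1,2-oxazol-4-yl on a saturated ring carbon. Within the data shown here, two measured steps concern the group that leaves, although neither removes it. Each exchanges one of its methyl groups for another group: 4-fluorophenyl gives a number 49 percentage points lower from compound 1 to compound 2 (beyond the scatter) and phenyl gives a number 66 percentage points lower from compound 1 to compound 3 (beyond the scatter) as a second large drop. Compound 4 gains neither of those groups, so neither drop is expected to carry over. Among the measured compounds shown here, no measured compound shows this exchange of one whole ring for another, which leaves the expectation uncertain. In this assay the expected step is a number 4 percentage points lower from compound 1 to compound 4 (within the scatter) and is estimated to stay within the scatter. Compound 4 is expected at 68% with an estimated range from 42% to 88% for a single measurement.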

Compound 4, percent of the compound remaining: 68%
Beside the measured number, compound 4's estimate shows no gap at the digits printed, within the range that was stated.
By their numbers in this assay, from the lowest: compound 3; then compound 2; then compounds 4 and 1 (each within the scatter of the next).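

In this assay, pyrimidin-5-yl in place of 3,5-dimethyl-1,2-oxazol-4-yl on this saturated ring carbon gives a number 4 percentage points lower from compound 1 to compound 4 (within the scatter), so a whole exchange of one aromatic ring for another at this position leaves no difference beyond the scatter in the share of compound remaining. The earlier compounds shown here showed only large drops, each from exchanging one methyl on the five-membered ring for a larger aromatic group; compound 4 shows that altering the group at this position need not lead to such a drop, even though the six-membered ring that enters has no methyl groups at all. No measured information explains why these two rings give results within the scatter of each other.

From the compounds shown here alone, all four compounds carry an aromatic ring at this position, so it remains open how a non-aromatic group, such as an amine like morpholin-4-yl or a simple propyl chain, would fare in this assay. Going by these compounds, it is also open whether adding phenyl to the pyrimidin-5-yl ring would bring the same kind of drop as on the five-membered ring.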